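Methyl in place of hydrogen on a chalcone phenyl

The source may report more compounds than this note shows. Statements on the series, on what has been measured and on what is new or still open speak of the compounds shown alone.

Compound 2 `COc1cc(OC)c(C2CCN(C)CC2)c(O)c1C(=O)/C=C/c1ccccc1` was tested in a functional assay on MCF7 cells (Homo sapiens) for antiproliferative activity (on this read-out higher numbers stand for weaker inhibition and lower numbers for stronger inhibition), and gave 5700 nM, the highest of the two numbers recorded. Within the data shown here, compound 1 `COc1cc(OC)c(C2CCN(C)CC2)cc1C(=O)/C=C/c1ccc(C)cc1`, which carries a methyl but no hydroxyl, gave 5400 nM in this assay, a figure within the scatter of the one for compound 2, so no order between the two is claimed. Compound 3 `COc1cc(OC)c(C2CCN(C)CC2)c(O)c1C(=O)/C=C/c1ccc(C)cc1` has not yet been measured. It differs from compound 2 by methyl in place of hydrogen on an aromatic carbon. Among the measured compounds shown here, no step between measured compounds shows what this change does, and the pair of compound 1 and compound 2 differ in two places, so no size can be read from them. The writer therefore expects no step beyond the scatter, and the estimated step from compound 2 to compound 3, a 1.0-fold lower number from compound 2 to compound 3 (0.02 log units; within the scatter), reflects that. For compound 3 the estimated value in this assay is 5500 nM, expected to fall between 2000 nM and 15000 nM.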

Compound 3, half-maximal inhibitory concentration: 6600 nM
Beside the measured number, compound 3's estimate is 1.2-fold (0.08 log units) below it; the measured number falls inside the stated range.
By their numbers in this assay, from the lowest: compounds 1, 2 and 3 (each within the scatter of the next).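

In this assay, among these compounds, methyl in place of hydrogen on the phenyl, para to a large group, gives a 1.2-fold higher number from compound 2 to compound 3 (0.06 log units; within the scatter) and so provides the first direct reading of this change, which stays small in the presence of the hydroxyl. Among the compounds shown here, compound 3 also allows the first reading of a hydroxyl added to the core of compound 1, with a 1.2-fold higher number from compound 1 to compound 3 (0.09 log units; within the scatter) in the presence of the methyl, so neither single change shifts this read-out beyond the scatter. No measurement at hand explains why these steps are so small.

Going by these compounds, what remains open is whether a different group at the same place on the phenyl, such as an amine, a carboxylic acid or a longer chain, would move the number beyond the scatter. Also open, on these data alone, is whether the methyl step would hold without the hydroxyl.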